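Removing a methyl from the cyclohexyl of compound 1

A few compounds are considered here, and "the series" means these few. Any claim that something is new, unique, unknown or untested is made for them only; others in the source may bear on it.

In an assay on isolated protein for inhibition of sphingosine kinase 1 (Homo sapiens) (a lower number here means a stronger inhibitor, a higher number a weaker inhibitor), compound 1 `CC1(c2nc(-c3ccc(CNC(=O)[C@H]4NCC[C@@H]4O)cc3)no2)CCCCC1` gives 210 nM. Of the two numbers in hand it is the higher one; the other belongs to compound 2 `CCCCCCCc1nc(-c2ccc([C@H](CC)NC(=O)[C@H]3NCC[C@@H]3O)cc2)no1`, which in this assay gives 30 nM, and the gap between the two lies beyond the usual scatter. Within the data shown here, compound 2 differs from compound 1 in several places at once, so what the pair shows is only that the two values stand apart, not which part of the difference carries it.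

Compound 3 `O=C(NCc1ccc(-c2noc(C3CCCCC3)n2)cc1)[C@H]1NCC[C@@H]1O` is compound 1 with one change: hydrogen in place of methyl on a saturated ring carbon. Read one bond further out, the 1-methylcyclohexyl becomes a cyclohexyl. Among the measured compounds shown here, no measured pair in this set isolates that change, so there is no step to lean on. The author expects a modest drift toward a higher number, of a size that may only just exceed the scatter, as a 1.5-fold higher number from compound 1 to compound 3 (0.18 log units; within the scatter). For compound 3 the estimate in this assay is 320 nM, with a plausible range from 120 nM to 850 nM.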

Compound 3, half-maximal inhibitory concentration: 380 nM
For compound 3 the middle estimate is 1.2-fold (0.07 log units) below the measured one; the range from low to high includes it.
By their numbers in this assay, from the lowest: compound 2; then compounds 1 and 3 (each within the scatter of the next).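

In this assay, among these compounds, hydrogen in place of methyl on a saturated ring carbon gives a 1.8-fold higher number from compound 1 to compound 3 (0.26 log units; within the scatter), and this is the first comparison in the set that isolates a single place in the structure. Among the compounds shown here, the earlier pair could show only that two values stood apart, whereas this one shows that the methyl of the 1-methylcyclohexyl, taken alone, carries no difference that can be told from the scatter, so compound 1 and compound 3 cannot be put in order. Nothing in the data given bears on why the two compounds fall so close together.

As far as these compounds go, what remains open is whether this ring carbon tolerates only the small exchange between methyl and hydrogen, or whether a different group there, such as an ethyl, a hydroxyl or an amine, would move the number beyond the scatter. From the compounds shown here alone, it also remains open whether the cyclohexyl itself matters, since a single step at one place says nothing about a smaller ring such as a cyclopropyl or about the other places in which compound 2 differs.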